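Swapping a methyl for a chloro on the amide ring

A few compounds are considered here, and "the series" means these few. Any claim that something is new, unique, unknown or untested is made for them only; others in the source may bear on it.

Of the compounds shown here, two of a shared core have been measured in a functional assay on HCC1937 cells (Homo sapiens) for antiproliferative activity, read by CCK-8 assay, with a stated time of 72 h; a higher number here means a weaker inhibitor, a lower number a stronger inhibitor. Compound 1 `O=C(Nc1cccc(-c2oc3cc(-c4ccc(F)cc4)ccc3c(=O)c2O)c1)c1ccc(F)cc1` gives 14200 nM. Among the measured compounds shown here, compound 2 `Cc1ccc(C(=O)Nc2cccc(-c3oc4cc(-c5ccc(F)cc5)ccc4c(=O)c3O)c2)cc1` gives 7110 nM, the lowest of the two numbers, with compound 1 as its only neighbour. For the measured compounds named here, the one step between them, a 2.0-fold lower number from compound 1 to compound 2 (0.30 log units; within the scatter), is within the scatter, so the two compounds cannot be told apart on these numbers.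

Compound 3 `O=C(Nc1cccc(-c2oc3cc(-c4ccc(F)cc4)ccc3c(=O)c2O)c1)c1ccc(Cl)cc1` is not yet measured. It differs from compound 2 in a single place: chloro in place of methyl on an aromatic carbon. Going by the values given here, the only measured step, the one from compound 1 to compound 2, bears on this change in a loose way, since it also exchanges one small group for another at the same place, and it stayed within the scatter. Among the compounds with values here, no measured step exchanges methyl for chloro. The expectation for compound 3 is therefore a step of about a 1.0-fold lower number from compound 2 to compound 3 (0.01 log units; within the scatter), that is, none beyond the scatter, in this assay. Compound 3 is estimated at 7000 nM, with a range from 3000 nM to 16000 nM.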

Compound 3, half-maximal inhibitory concentration: 4030 nM
Compound 3: middle estimate off by 1.7-fold (0.24 log units), on the high side, within the range that was stated.
By their numbers in this assay, from the lowest: compounds 3, 2 and 1 (each within the scatter of the next, the first and the last beyond it).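

In this assay, the step with chloro in place of methyl, a 1.8-fold lower number from compound 2 to compound 3 (0.25 log units; within the scatter), stays within the scatter, so these two groups cannot be told apart at this place on the ring, para to a large group. Among the compounds shown here, the step with chloro in place of fluoro, a 3.5-fold lower number from compound 1 to compound 3 (0.55 log units; beyond the scatter), is modest but is the only one of the three steps that lies beyond the scatter, so it gives the first sign that a single-atom exchange at this ring position can move the number by more than repeat measurements would. Compound 2 lies within the scatter of both other compounds, and no measurement shown here explains the difference between the chloro and fluoro compounds.

The compounds shown carry only fluoro, methyl or chloro at this place, so it remains open how the number would respond to a methoxy group, a trifluoromethyl group, an amine or a carboxylic acid there. As far as these compounds go, it also remains open whether the gap between the chloro and fluoro compounds would hold on another core or in another cell line.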